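A Halogen Swap and Inhibition of Kynurenine 3-Monooxygenase

The compounds below may be only part of what the source reports. "The series", "measured", "known", "first", "only" and "open" are said of these compounds alone.

Compound 3 `COC(=O)C(=N)/C=C(\O)c1ccc(Cl)cc1` gives 13% in an assay for inhibition of kynurenine 3-monooxygenase (Rattus norvegicus), tested at 10 uM (a higher number here means more inhibition at the concentration tested (going by the name of the read-out), a lower number less inhibition), the second highest of three numbers. Compound 1 `COC(=O)C(=O)/C=C(\O)c1cccc(Cl)c1Cl` gives 14% and compound 2 `COC(=O)C(=N)/C=C(\O)c1ccccc1` gives 3%, both within the scatter of compound 3. Among the measured compounds shown here, the only single-site step, a number 10 percentage points higher from compound 2 to compound 3 (within the scatter), arises from chloro in place of hydrogen on an aromatic carbon and stays within the scatter. Compound 4 `COC(=O)C(=N)/C=C(\O)c1ccc(Br)cc1` differs from compound 3 by bromo in place of chloro on an aromatic carbon. For the measured compounds named here, no measured step covers bromo in place of chloro, and the one step that exists, also on an aromatic carbon, was small. Compound 4 is therefore expected to shift by a number 2 percentage points higher from compound 3 to compound 4 (within the scatter), not beyond the scatter. The estimate for compound 4 is 15%, between 3% and 28%.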

Compound 4, a percentage reported as inhibition, at one concentration (the size of the read-out at that concentration, not a potency): 0%
The estimate for compound 4 lay 15 percentage points above the measured number, and the stated range ends above it.
By their numbers in this assay, from the lowest: compounds 4, 2, 3 and 1 (each within the scatter of the next, the first and the last beyond it).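

Among the compounds shown here, the step of a number 13 percentage points lower from compound 3 to compound 4 (beyond the scatter) is the only single-site step in this assay that passes the scatter, so at this place the choice between the two halogens counts. Bromo does not separate from hydrogen, though, since the step of a number 3 percentage points lower from compound 2 to compound 4 (within the scatter) stays within the scatter. Nothing in hand explains why chloro and bromo part here.

On these data alone, whether fluoro, methoxy or an amine at this place would lift the read-out remains open. So does whether the chloro and bromo difference holds on the core of compound 1.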